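The source may hold more compounds than are shown below. What is called first, only, known or untested is meant among the compounds shown, and "the series" means these compounds.

Compound 2 `O=C(CSc1nnc(-c2ccncc2)n1-c1ccccc1)N/N=C/c1ccc(Cl)cc1` gives 11000 nM in a functional assay on HepG2 cells (Homo sapiens) for inhibition, read by MTT assay, with a stated time of 48 h (a higher number here means a weaker inhibitor, a lower number a stronger inhibitor), the lowest of the two numbers, with compound 1 `COc1ccc(/C=N/NC(=O)CSc2nnc(-c3ccncc3)n2-c2ccccc2)cc1` at 27100 nM. For the measured compounds named here, the one measured step, a 2.5-fold lower number from compound 1 to compound 2 (0.39 log units; beyond the scatter), was modest. Compound 3 `O=C(CSc1nnc(-c2ccncc2)n1-c1ccccc1)N/N=C/c1cc(Br)ccc1O` differs from compound 2 by 5-bromo-2-hydroxyphenyl in place of 4-chlorophenyl on a carbon with a double bond to nitrogen. Going by the values given here, no measured step bears directly on a bromine with a hydroxyl, so the only guide is that a halogen swap changed the number modestly. Compound 3 is therefore expected to sit near compound 2, estimated at 9000 nM with a range from 3000 nM to 27000 nM, a step of a 1.2-fold lower number from compound 2 to compound 3 (0.09 log units; within the scatter).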

Compound 3, half-maximal inhibitory concentration: 4390 nM
Compound 3: middle estimate off by 2.1-fold (0.31 log units), on the high side, within the range that was stated.
By their numbers in this assay, from the lowest: compound 3; then compound 2; then compound 1.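

At this position, on a carbon with a double bond to nitrogen, the ring can carry both a hydroxyl and a bromine and the number still falls: 5-bromo-2-hydroxyphenyl gives a 2.5-fold lower number from compound 2 to compound 3 (0.40 log units; beyond the scatter) in this assay and, set against 4-methoxyphenyl, a 6.2-fold lower number from compound 1 to compound 3 (0.79 log units; beyond the scatter) in the same test. Nothing here gives a reason for these steps.

The change brings in the hydroxyl and the bromine together, so the compounds shown cannot tell which of them carries the step. As far as these compounds go, how an amine or a carboxylic acid on this ring would read also stays open.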